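This account rests on a few compounds, and the source may have more. Where it says the series, first, only, none or still open, it means among the compounds named here.

Compound 1 `COc1ccccc1OCCNc1ccc(=O)n(Cc2ccc(OC(F)F)c(OC3CCCC3)c2)n1` gives 9100 nM in a functional assay on K562 cells (Homo sapiens) for antiproliferative activity, read by MTT assay, with a stated time of 48 h; a lower number here means a stronger inhibitor of growth, a higher number a weaker inhibitor of growth. Compound 2 `COc1ccccc1OCCNc1ccc(=O)n(Cc2ccc(OC(F)F)c(OCC3CC3)c2)n1` gives 60900 nM in this assay. Compound 3 `COc1ccccc1OCCNc1cnn(Cc2ccc(OC(F)F)c(OCC3CC3)c2)c(=O)c1Cl` gives 67600 nM in this assay.

Compound 4 `COc1ccccc1OCCNc1cnn(Cc2ccc(OC(F)F)c(OC3CCCC3)c2)c(=O)c1Cl` has not yet been measured. Compounds 1 and 2 share one core and differ in a single place, (cyclopentyl in place of cyclopropylmethyl on an oxygen on an aromatic ring), and that change gave a 6.7-fold lower number from compound 2 to compound 1 (0.83 log units; beyond the scatter). Compound 3 carries a different core from compound 2; the difference between the two cores is not broken down here, and the values of compound 2 and compound 3 lie within the scatter of each other. Compound 4 stands to compound 3 as compound 1 stands to compound 2: the change is cyclopentyl in place of cyclopropylmethyl on an oxygen on an aromatic ring, the same change at the same place. Because the same change once gave a 6.7-fold lower number from compound 2 to compound 1 (0.83 log units; beyond the scatter), a comparable step is expected on the core of compound 3, although with a single example there is no check on how fully it carries over. The step expected is a 5.6-fold lower number from compound 3 to compound 4 (0.75 log units; beyond the scatter). Compound 4 is accordingly estimated at 12000 nM, most likely between 4000 nM and 40000 nM.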

Compound 4, concentration for 50% growth inhibition: > 100000 nM
Compound 4: only a limit was reported; the forecaster's own chance of this, stated with the estimate: 5%; at least 8.3-fold (0.92 log units) between middle value and limit.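

Cyclopentyl in place of cyclopropylmethyl gave a 6.7-fold lower number from compound 2 to compound 1 (0.83 log units; beyond the scatter), whereas the same change on the other core gave an at least 1.4-fold higher number from compound 3 to compound 4 (0.17 log units; that floor lies within the scatter). The two steps do not agree, so in these two pairs the change did not carry over from one core to the other: the same change on two cores in this assay, a 6.7-fold lower number (0.83 log units; beyond the scatter) from compound 2 to compound 1 and an at least 1.4-fold higher number (0.17 log units; that floor lies within the scatter) from compound 3 to compound 4, at least 9.8-fold (0.99 log units) apart, beyond the scatter of two such steps

In this assay compound 4 gives > 100000 nM, which is a limit of the assay and not a number, so the full size of its step stays unknown, and two pairs cannot show what in the cores sets the steps apart: the limit of > 100000 nM in this assay, at which 1 of the 4 values shown sits.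

The compounds shown leave open how other groups on this oxygen, such as cyclobutyl or cyclohexyl, would behave on the core of compound 1 and the core of compound 3. They also leave open whether the gap between the two cores would recur with such groups or is confined to the change from cyclopropylmethoxy to cyclopentyloxy.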